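The compounds below may be only part of what the source reports. "The series", "measured", "known", "first", "only" and "open" are said of these compounds alone.

Measured so far:
compound 1 `CNC(=O)c1cc(Oc2ccc3nc(NC(=O)Nc4cc(C(F)(F)F)cc(C(F)(F)F)c4)sc3c2)ccn1`: 98.4%
compound 2 `CNC(=O)c1cc(Oc2ccc3nc(NC(=O)Nc4ccc(Cl)cc4)sc3c2)ccn1`: 85.2%

In a functional assay on HCT-116 cells (Homo sapiens) for inhibition, read by MTT assay, with a stated time of 2 days, tested at 100 uM (on this read-out lower numbers stand for less inhibition of growth and higher numbers for more inhibition of growth at the one concentration tested), compound 1 gives 98.4%, while compound 2 gives 85.2%, the lower of the two numbers, compound 1 standing higher by more than the scatter. Compound 3 `CNC(=O)c1cc(Oc2ccc3nc(NC(=O)Nc4ccc(Br)cc4)sc3c2)ccn1` is not yet measured; it differs from compound 2 by bromo in place of chloro on an aromatic carbon. Among the measured compounds shown here, no measured pair covers this exchange, so its size in this assay is open; the expectation is a small step, if any beyond the scatter, with uncertain direction. Compound 3 is therefore expected to give 87%, in the range 74% to 96%. The expected step is a number 1.8 percentage points higher from compound 2 to compound 3 (within the scatter).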

Compound 3, percent growth inhibition at one concentration: 80%
Beside the measured number, compound 3's estimate is 7 percentage points above it; the measured number falls inside the stated range.
By their numbers in this assay, from the lowest: compounds 3 and 2 (each within the scatter of the next); then compound 1.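

In this assay, the exchange of chloro for bromo, on an aromatic carbon para to a large group, reads a number 5.2 percentage points lower from compound 2 to compound 3 (within the scatter). At this position and at the one concentration tested, the two halogens therefore cannot be told apart. No measurement on hand offers an explanation for the size of this step.

As far as these compounds go, whether fluoro or another small halogen would behave the same way remains open. So does what an amine, a methoxy group or a carboxylic acid would do at this position.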